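The source may report more compounds than this note shows. Statements on the series, on what has been measured and on what is new or still open speak of the compounds shown alone.

Values measured in a functional assay on A549 cells (Homo sapiens) for antiproliferative activity, read by MTT assay, with a stated time of 72 h (on this read-out lower numbers stand for stronger inhibition and higher numbers for weaker inhibition), are as follows:

Compound 1 `O=C(N/N=C/c1ccccc1)Nc1ccc(Oc2ccnc3[nH]ccc23)c(F)c1` gives 2500 nM
Compound 2 `COc1ccc(/C=N/NC(=O)Nc2ccc(Oc3ccnc4[nH]ccc34)c(F)c2)cc1` gives 3980 nM
Compound 3 `CN(C)CCn1cccc1/C=N/NC(=O)Nc1ccc(Oc2ccnc3[nH]ccc23)c(F)c1` gives "not active" (no number reported)

Compound 3 stands without a number, since it is reported only as "not active" (no number reported) and offers no value to step from. Compound 4 `O=C(N/N=C/c1cccn1CCCN1CCCCC1)Nc1ccc(Oc2ccnc3[nH]ccc23)c(F)c1` differs from compound 3 by (piperidin-1-yl)methyl in place of dimethylamino on a saturated chain carbon, two bonds along the chain from an aromatic nitrogen and the same change can be read as 2-(dimethylamino)ethyl to 3-(piperidin-1-yl)propyl. Within the data shown here, the only measured step, a 1.6-fold higher number from compound 1 to compound 2 (0.20 log units; within the scatter), is methoxy in place of hydrogen on an aromatic carbon, a different change that says nothing about this chain. The data therefore set no size or direction for the step in this assay and only an uncertain expectation is possible. The closest guide is compound 3 at "not active" (no number reported) and so a weak result is expected, with a report lacking any number still quite possible. Compound 4 is estimated at 5000 nM with an expected range from 1200 nM to 20000 nM if a number is obtained.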

Compound 4, half-maximal inhibitory concentration: 2850 nM
Beside the measured number, compound 4's estimate is 1.8-fold (0.24 log units) above it; measured number inside the range.
By their numbers in this assay, from the lowest: compounds 1, 4 and 2 (each within the scatter of the next).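

Among these compounds, compound 3 carries no number in this assay, so no step from it to compound 4 can be read. The compounds shown leave open what replacing 2-(dimethylamino)ethyl with 3-(piperidin-1-yl)propyl does on its own. No measurement shown offers an explanation for the result.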